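This account rests on a few compounds, and the source may have more. Where it says the series, first, only, none or still open, it means among the compounds named here.

Three compounds have been measured in an assay on HEK293 cells for positive allosteric modulation of metabotropic glutamate receptor 5 (Homo sapiens), read by FLIPR, with a stated time of 1 h; a higher number here means that more compound is needed for the effect, a lower number that less compound is needed:

Compound 1: `O=C(C1CC(F)C1)N1CCc2nc(C#Cc3ccccc3)sc2C1`, giving 85 nM
Compound 2: `O=C(C1CCOCC1)N1CCc2nc(C#Cc3ccccc3)sc2C1`, giving 290 nM
Compound 3: `Cc1nc(C(=O)N2CCc3nc(C#Cc4ccccc4)sc3C2)cs1`, giving 220 nM

Compound 3 stands second highest of the three numbers. The step of a 1.3-fold lower number from compound 2 to compound 3 (0.12 log units; within the scatter) lies within the scatter, whereas a 2.6-fold higher number from compound 1 to compound 3 (0.41 log units; beyond the scatter) is beyond it.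

Compound 4, `O=S(=O)(C1CC1)N1CCc2nc(C#Cc3ccccc3)sc2C1`, has not yet been measured. It differs from compound 3 in one place: cyclopropylsulfonyl in place of (2-methyl-1,3-thiazol-4-yl)carbonyl on an amine nitrogen in a ring.

The measured steps all exchange the group on the carbonyl carbon while keeping the carbonyl itself: a 3.4-fold higher number from compound 1 to compound 2 (0.53 log units; beyond the scatter) and a 2.6-fold higher number from compound 1 to compound 3 (0.41 log units; beyond the scatter) were modest, and a 1.3-fold lower number from compound 2 to compound 3 (0.12 log units; within the scatter) stayed within the scatter. Among the compounds with values here, none of them replaces a carbonyl by a sulfonyl, so no measured step bears directly on the change into compound 4. Within the data shown here, what they do show is that a small saturated ring on the carbonyl, in compound 1, gave the lowest number so far, 85 nM. A small ring also enters in compound 4, so in this assay a number near the measured ones is expected, with the step of a 1.5-fold lower number from compound 3 to compound 4 (0.17 log units; within the scatter) expected to be small and uncertain in direction. Compound 4 is estimated at 150 nM, within a range of 40 nM to 600 nM.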

Compound 4, half-maximal effective concentration: > 10000 nM
Compound 4: a limit, no number; the forecaster's own chance of this, stated with the estimate: 10%; middle value at least 66-fold (1.82 log units) from the limit.
By their numbers in this assay, from the lowest: compound 1; then compounds 3 and 2 (each within the scatter of the next). At a limit, above all of these: compound 4.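

In this assay, compound 4 gives a limit and not a number: the limit of > 10000 nM in this assay, at which 1 of the 4 values shown sits.

The steps to it are all large: an at least 45-fold higher number from compound 3 to compound 4 (1.65 log units; beyond the scatter), an at least 34-fold higher number from compound 2 to compound 4 (1.53 log units; beyond the scatter) and an at least 110-fold higher number from compound 1 to compound 4 (2.07 log units; beyond the scatter). Exchanging the group on the carbonyl had moved the number only modestly or not beyond the scatter, whereas this first change at the amine nitrogen in a ring, from a carbonyl-linked group to cyclopropylsulfonyl, shows that this position tolerates far less than those compounds suggested.

The compounds shown leave open whether the sulfonyl or the three-membered ring accounts for the jump, as both enter together. Cyclopropylcarbonyl on the same nitrogen would separate the two, and methylsulfonyl or phenylsulfonyl would test whether other sulfonyl groups behave the same way.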